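A few compounds are considered here, and "the series" means these few. Any claim that something is new, unique, unknown or untested is made for them only; others in the source may bear on it.

Compound 1 `COc1nc(-c2ccc(Cl)cc2)cc(-c2ccc(Cl)cc2Cl)c1C#N` is one of three close relatives that share the same core and differ only in one aromatic group. In a functional assay on trachea (Cavia porcellus) for activation (on this read-out higher numbers stand for weaker inhibition and lower numbers for stronger inhibition), compound 1 gives 7550 nM. Compound 2 `COc1ccc(-c2cc(-c3ccc(Cl)cc3Cl)c(C#N)c(OC)n2)cc1OC` gives 7910 nM in this assay, and compound 3 `CCOc1nc(-c2cccs2)cc(-c2ccc(Cl)cc2Cl)c1C#N` gives 8710 nM. The three numbers lie within the usual scatter of one another, so compound 1 cannot be set apart from compound 2 or compound 3 on this read-out; all three inhibit only weakly here.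

Compound 4 `COc1nc(-c2ccncc2)cc(-c2ccc(Cl)cc2Cl)c1C#N` has not yet been measured. It differs from compound 1 by a single change: pyridin-4-yl in place of 4-chlorophenyl on an aromatic carbon. So far, exchanging the aromatic group at this place among the three measured compounds has moved the number no further than the scatter allows, as the values of compound 1, compound 2 and compound 3 show. Among the compounds with values here, no measured pair shows what a ring nitrogen in this group does, so the expectation rests only on that tolerance. The expected step of a 1.3-fold higher number from compound 1 to compound 4 (0.12 log units; within the scatter) is small, leaning toward a slightly higher number, and may well stay within the scatter. Compound 4 is therefore expected to give 10000 nM in this assay, with a likely range from 4000 nM to 30000 nM.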

Compound 4, half-maximal inhibitory concentration: 11800 nM
The estimate for compound 4 lay 1.2-fold (0.07 log units) below the measured number; the measured number falls inside the stated range.
By their numbers in this assay, from the lowest: compounds 1, 2, 3 and 4 (each within the scatter of the next).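

In this assay, within the data shown here, pyridin-4-yl in place of 4-chlorophenyl gives a 1.6-fold higher number from compound 1 to compound 4 (0.19 log units; within the scatter), so this place on the shared core accepts a ring that carries a nitrogen and a hydrogen-bond acceptor, with no step that can be told from the scatter. This is the first step shown between two compounds that differ in one place only, and it gives a direct reading where the earlier compounds offered only a side-by-side view of their values. No measurement here bears on why the number stays within the scatter for this change.

The step also swaps two things at once, the chlorine leaving and the ring nitrogen entering, so a plain phenyl group would be needed to read each one alone, and a pyridin-2-yl or pyridin-3-yl group would show whether the place of the nitrogen in the ring matters. Every number shown so far stands for weak inhibition, and whether a group of another kind at this place, such as an amine, a carboxylic acid or a longer chain, could give a clearly lower number remains open.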